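This account rests on a few compounds, and the source may have more. Where it says the series, first, only, none or still open, it means among the compounds named here.

Measured compounds:
Compound 1 `O=C(Nc1ccc(F)c(-c2nc3ncc(-c4ccc(F)cc4F)cc3[nH]2)c1)N1CCCC1`: 9500 nM
Compound 2 `O=C(Nc1ccc(F)c(-c2nc3ncc(-c4ccc(F)cc4)cc3[nH]2)c1)N1CCCC1`: 6270 nM
Compound 3 `O=C(Nc1ccc(F)c(-c2nc3ncc(-c4cccc(F)c4)cc3[nH]2)c1)N1CCCC1`: 7000 nM

In an ADME assay on the whole organism (Mus musculus, strain Swiss Webster) for pharmacokinetics, read by LC-MS, at a dose of 50 mg/kg by the oral route (a higher number here means more compound in the circulation at the dose given, a lower number less compound in the circulation), the three measured compounds sit close together. The difference between the cores of compound 2 and compound 3 is 3-fluorophenyl in place of 4-fluorophenyl on an aromatic carbon, and the step between them is a 1.1-fold higher number from compound 2 to compound 3 (0.05 log units; within the scatter). From compound 2 to compound 1 the change is fluoro in place of hydrogen on an aromatic carbon, giving a 1.5-fold higher number from compound 2 to compound 1 (0.18 log units; within the scatter).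

Compound 4 `O=C(Nc1ccc(F)c(-c2nc3ncc(-c4cc(F)cc(F)c4)cc3[nH]2)c1)N1CCCC1` is not yet measured. It differs from compound 3 by fluoro in place of hydrogen on an aromatic carbon. This is the same kind of change as from compound 2 to compound 1, though the place differs: in compound 4 the fluoro is meta to a fluoro group and meta to a large group, whereas in compound 1 it is ortho to a large group and meta to a fluoro group. Because the earlier step was a 1.5-fold higher number from compound 2 to compound 1 (0.18 log units; within the scatter), a step of similar size is expected, a 1.1-fold higher number from compound 3 to compound 4 (0.06 log units; within the scatter). Compound 4 is estimated at 8000 nM, between 4000 nM and 16000 nM.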

Compound 4, maximal plasma concentration: 4800 nM
Estimate against measurement, compound 4: 1.7-fold (0.22 log units) above; low and high end bracket the measured number.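

In this assay, adding the fluoro gives steps on the two cores that do not differ beyond what repeated measurement allows: the same change on two cores in this assay, a 1.5-fold higher number (0.18 log units; within the scatter) from compound 2 to compound 1 and a 1.5-fold lower number (0.16 log units; within the scatter) from compound 3 to compound 4, 2.2-fold (0.34 log units) apart, within the scatter of two such steps. The other readings agree, with a 1.5-fold lower number from compound 3 to compound 4 (0.16 log units; within the scatter), alongside a 1.3-fold lower number from compound 2 to compound 4 (0.12 log units; within the scatter) and a 2.0-fold lower number from compound 1 to compound 4 (0.30 log units; within the scatter), so the four compounds cannot be told apart here. This does not show that the change carries from one core to another, nor that it reverses: the two steps point in opposite directions, but steps of this size settle neither reading.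

The compounds shown leave open how the number responds to a group other than fluoro on the phenyl group, such as a methoxy group, an amine or a carboxylic acid. They also leave open whether any such group would move it beyond the scatter.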